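Methyl in place of methoxy on the shared core

This account rests on a few compounds, and the source may have more. Where it says the series, first, only, none or still open, it means among the compounds named here.

Measured so far:
compound 1 `N=C(NCc1ccccc1)[C@@H]1CCC(=O)N1Cc1ccccc1` — 16.6%
compound 2 `COc1ccc(CN2C(=O)CC[C@H]2C(=N)NCc2ccccc2)cc1` — 12.3%

In a functional assay on SH-SY5Y cells (Homo sapiens) for cytotoxicity, read by MTT assay, with stated times of 8 h, 30 min and 12 h, tested at 0.05 uM (a lower number here means a weaker effect, a higher number a stronger effect of the compound at the concentration tested), compound 1 gives 16.6% and compound 2 gives 12.3%. Compound 2 holds the smaller of the two figures, but the gap to compound 1 is within the scatter. Compound 3 `Cc1ccc(CN2C(=O)CC[C@H]2C(=N)NCc2ccccc2)cc1` differs from compound 2 by methyl in place of methoxy on an aromatic carbon. For the measured compounds named here, the one step that bears on it, a number 4.3 percentage points lower from compound 1 to compound 2 (within the scatter), touched the same aromatic carbon and stayed within the scatter. No shift beyond the scatter is therefore expected, the estimated step being a number 1.7 percentage points higher from compound 2 to compound 3 (within the scatter). Compound 3 is expected to give 14%, within a range of 4% to 25%.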

Compound 3, a percentage reported as activity, at one concentration (the size of the read-out at that concentration, not a potency): 17.1%
Estimate against measurement, compound 3: 3.1 percentage points below, and the stated range covers the measured number.
By their numbers in this assay, from the lowest: compounds 2, 1 and 3 (each within the scatter of the next).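

With the step of a number 4.8 percentage points higher from compound 2 to compound 3 (within the scatter) and the step of a number 0.5 percentage points higher from compound 1 to compound 3 (within the scatter), the aromatic carbon para to a large group has now carried hydrogen, methoxy and methyl, and every step among the three lies within the scatter. Methyl, with no hydrogen-bond acceptor, therefore reads the same as methoxy, with one, at this carbon and at this single concentration. No evidence on the reason for these numbers is available. Open, as far as these compounds go, is whether an amine, a carboxylic acid or a longer chain at this carbon would produce a step beyond the scatter.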